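The source may hold more compounds than are shown below. What is called first, only, known or untested is meant among the compounds shown, and "the series" means these compounds.

Measured compounds in a functional assay on BEL-7404 cells for cytotoxicity against BEL-7404 tumor cell line (Homo sapiens), read by MTT assay, with a stated time of 48 h; a higher number here means a weaker inhibitor, a lower number a stronger inhibitor — each of the three values is a limit of the assay, not a number:

Compound 1, `Cc1ccc2[nH]c(=O)c(-c3nc4cc([N+](=O)[O-])ccc4[nH]3)cc2c1`: > 100000 nM
Compound 2, `O=c1[nH]c2ccccc2cc1-c1nc2cc([N+](=O)[O-])ccc2[nH]1`: > 100000 nM
Compound 3, `COc1ccc2[nH]c(=O)c(-c3nc4cc(Br)ccc4[nH]3)cc2c1`: > 100000 nM

Compound 3 stands where every measured compound of the series stands: at the limit, (the limit of > 100000 nM in this assay, at which 3 of the 3 values shown sit). Its value is a limit and nothing finer is known of it.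

Going by the values given here, the one step between measured compounds, hydrogen in place of methyl on an aromatic carbon, is a step that the two limits leave unreadable from compound 1 to compound 2; both ends are limits, so it gives no readable size and no direction.

The next compound, compound 4, is `COc1ccc2[nH]c(=O)c(-c3nc4cc([N+](=O)[O-])ccc4[nH]3)cc2c1`. It differs from compound 3 by nitro in place of bromo on an aromatic carbon. Compound 4 is also the nitro congener of compound 1 and compound 2, which differ from it only in the substituent on the core; both sit at the limit.

Among the compounds with values here, no measured step bears on this change with a readable size. Because the limit of > 100000 nM in this assay, at which 3 of the 3 values shown sit, holds for all three values shown, the expectation for compound 4 is that it too will be reported as a limit rather than a number. The step from compound 3 to compound 4 is estimated as a step that the limit leaves unreadable from compound 3 to compound 4. Compound 4 is expected at 150000 nM, with a range of 60000 nM to 500000 nM.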

Compound 4, half-maximal inhibitory concentration: > 100000 nM
Compound 4: a limit, no number (the forecaster's own chance of this, stated with the estimate: 85%); the middle value lies beyond the limit too.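

In this assay compound 4 gives > 100000 nM, a limit of the assay and not a number. No new step can be read among compound 1, compound 2, compound 3 and compound 4, as all four values are limits, and the series stands as follows: the limit of > 100000 nM in this assay, at which 4 of the 4 values shown sit.

The compounds shown leave open whether any change to the shared core would give a readable value, and how large any of these steps is.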